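The source may hold more compounds than are shown below. What is called first, only, known or untested is meant among the compounds shown, and "the series" means these compounds.

In a physicochemical assay for solubility, with a stated time of 4 h, at pH 7.4 (a higher number here means a more soluble compound, a lower number a less soluble compound), compound 1 (`Cc1cc(/C=C/C#N)cc(C)c1Oc1cc(Nc2ccc(C#N)cc2)c(N)cc1[N+](=O)[O-]`) gives 0.29 ug/mL and ranks second highest of three, with compound 2 (`Cc1cc(CCC#N)cc(C)c1Oc1cc(Nc2ccc(C#N)cc2)c(N)cc1CO`) highest (18.8 ug/mL) and compound 3 (`Cc1cc(CCC#N)cc(C)c1Oc1cc(Nc2ccc(C#N)cc2)c(N)cc1C(N)=O`) lowest (0.06 ug/mL). Compound 4 (`Cc1cc(/C=C/C#N)cc(C)c1Oc1cc(Nc2ccc(C#N)cc2)c(N)cc1C(F)(F)F`) differs from compound 1 by a single change (trifluoromethyl in place of nitro on an aromatic carbon), with trifluoromethyl in place of nitro on an aromatic carbon. Within the data shown here, the one measured step of this kind has carbamoyl in place of hydroxymethyl on an aromatic carbon (a 310-fold lower number from compound 2 to compound 3 (2.50 log units; beyond the scatter)), and it is large. It shows that one such swap can move the number far, but neither nitro nor trifluoromethyl takes part in it, so it offers no direction here. The step expected in this assay is therefore modest, with an estimate of a 1.2-fold lower number from compound 1 to compound 4 (0.06 log units; within the scatter) and wide uncertainty on either side. For compound 4 the estimated value is 0.25 ug/mL (expected range 0.05 ug/mL to 1.2 ug/mL).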

Compound 4, solubility: 0.24 ug/mL
For compound 4 the middle estimate is 1.0-fold (0.02 log units) above the measured one; low and high end bracket the measured number.
By their numbers in this assay, from the lowest: compound 3; then compounds 4 and 1 (each within the scatter of the next); then compound 2.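

In this assay, trifluoromethyl in place of nitro on this aromatic carbon gives a 1.2-fold lower number from compound 1 to compound 4 (0.08 log units; within the scatter) and so leaves the two compounds indistinguishable. Among these compounds, this is the first direct reading of a swap involving either group, and it shows that nitro, with its 2 hydrogen-bond acceptors, can give way to trifluoromethyl, with none, without a step beyond the scatter. Nothing measured here explains this result. On these data alone, whether an amine or a carboxylic acid on this carbon would move the number stays open. So does whether this swap would read the same with other groups elsewhere on the core of compound 1.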